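The compounds below may be only part of what the source reports. "The series", "measured", "known", "first", "only" and "open" are said of these compounds alone.

Compound 2 `OC[C@H]1O[C@@H](n2cnc3c(NCc4ccc(Cl)c(Cl)c4)ncnc32)[C@H](O)[C@@H]1O` is one of two measured compounds that share the same sugar-bearing core, the other being compound 1 `OC[C@H]1O[C@@H](n2cnc3c(NCc4ccc(Br)cc4)ncnc32)[C@H](O)[C@@H]1O`. In a functional assay on B16 cells (Mus musculus) for antiproliferative activity, with a stated time of 72 h (a higher number here means a weaker inhibitor, a lower number a stronger inhibitor), compound 2 gives > 166000 nM, which is a limit of the assay and not a number. In this assay compound 1 likewise gives > 166000 nM, again a limit rather than a number. Going by the values given here, because both values sit at the limit of > 166000 nM in this assay, at which 2 of the 2 values shown sit, the only measured step, a step that the two limits leave unreadable from compound 1 to compound 2, cannot be read, and so nothing measured shows how exchanging the group on the saturated chain carbon bound to a nitrogen on an aromatic ring moves potency. Compound 3 `COc1cccc(CNc2ncnc3c2ncn3[C@@H]2O[C@H](CO)[C@@H](O)[C@H]2O)c1O` is not yet measured; it differs from compound 2 in one place: 2-hydroxy-3-methoxyphenyl in place of 3,4-dichlorophenyl on a saturated chain carbon bound to a nitrogen on an aromatic ring. No readable measured step bears on this change. Compound 3 is expected to behave much as its measured neighbour did, with an expected step that the limit leaves unreadable from compound 2 to compound 3, that is, nothing beyond the scatter and most likely another limit. Compound 3 is therefore estimated at 200000 nM, within a range of 50000 nM to 800000 nM.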

Compound 3, half-maximal inhibitory concentration: > 166000 nM
Compound 3 ended at the assay's limit; the forecaster's own chance of this, stated with the estimate: 80%; the middle value does not contradict the limit.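

No new step can be read among compound 1, compound 2 and compound 3, because each result in this assay is a limit of the assay and not a number: the limit of > 166000 nM in this assay, at which 3 of the 3 values shown sit. The compounds shown leave open whether any group on the saturated chain carbon bound to a nitrogen on an aromatic ring changes potency in this assay at all.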